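Methylsulfonyl on the benzylidene ring of compound 2

The source may report more compounds than this note shows. Statements on the series, on what has been measured and on what is new or still open speak of the compounds shown alone.

Measured compounds:
compound 1, `CN(CC1CCC/C(=C\c2ccccc2)C1=O)c1ccccc1`: 69.7%
compound 2, `Cc1ccc(N(C)CC2CCC/C(=C\c3ccccc3)C2=O)cc1`: 81%
compound 3, `Cc1cccc(N(C)CC2CCC/C(=C\c3ccccc3)C2=O)c1`: 76.7%

Of the compounds shown here, three share the same core and have been measured in a functional assay on the whole organism (strain Kunming) for inhibition, with Mus musculus as the target, in the writhing test, with stated times of 1 h and 15 min, at a dose of 200 mg/kg by the oral route; a lower number here means less inhibition, a higher number more inhibition at the dose given (going by the name of the read-out). Compound 2 gives 81% and holds the highest number of the three; compound 3 stands nearest, and compound 1 furthest below it.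

The measured steps all concern the aryl group on the amine nitrogen. a number 11.3 percentage points higher from compound 1 to compound 2 (beyond the scatter). a number 7 percentage points higher from compound 1 to compound 3 (within the scatter). a number 4.3 percentage points lower from compound 2 to compound 3 (within the scatter). For the measured compounds named here, only the step from compound 1 to compound 2 lies beyond the scatter.

Compound 4, `Cc1ccc(N(C)CC2CCC/C(=C\c3ccc(S(C)(=O)=O)cc3)C2=O)cc1`, differs from compound 2 at a different place, the six-membered aromatic ring of carbon only attached to the exocyclic double bond: methylsulfonyl in place of hydrogen on an aromatic carbon. Going by the values given here, none of the measured steps touches this ring, and none introduces a group like methylsulfonyl, so no measured step bears directly on this change. The three numbers lie within a fairly narrow band, which gives no reason to expect a large step in either direction; the expectation is therefore no step beyond the scatter, with a wide range because the change is of a kind not yet sampled.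

Compound 4 is estimated to give 74%, with a range from 50% to 90%. This estimate corresponds to an expected a number 7 percentage points lower from compound 2 to compound 4 (within the scatter).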

Compound 4, a percentage reported as inhibition, in the whole organism at one dose (the size of the read-out at that dose, not a potency): 84.5%
The estimate for compound 4 lay 10.5 percentage points below the measured number, and the stated range covers the measured number.
By their numbers in this assay, from the lowest: compounds 1, 3, 2 and 4 (each within the scatter of the next, the first and the last beyond it).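

In this assay, for the compounds shown here, methylsulfonyl in place of hydrogen on the ring attached to the exocyclic double bond gives a number 3.5 percentage points higher from compound 2 to compound 4 (within the scatter), the first reading for a change at this ring. The earlier compounds shown here varied only the aryl group on the amine nitrogen, whereas this result shows that the position accepts methylsulfonyl, on an aromatic carbon para to a large group, without a step beyond the scatter, and that inhibition at this dose stays in the range of compound 2. Nothing available on this series accounts for the result or shows how the group acts at this position.

Open, from the compounds shown here alone, is whether a carboxylic acid, an amine or a simple fluorine in the same place would also stay within the scatter of compound 2, and whether methylsulfonyl would give a similar step with the unsubstituted phenyl on the amine nitrogen of compound 1. Going by these compounds, since the read-out comes from one dose, how compound 2 and compound 4 would compare at lower doses also stays open.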